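The compounds below may be only part of what the source reports. "The series", "measured", "known", "first", "only" and "open" are said of these compounds alone.

Compound 1, with the structure `c1ccc2[nH]c(-n3cccn3)cc2c1`, was tested in a functional assay on MCF7 cells (Homo sapiens) for cytotoxicity, read by MTT assay, with a stated time of 72 h; on this read-out lower numbers stand for stronger inhibition and higher numbers for weaker inhibition. In this assay compound 1 gives only a limit, > 100000 nM, not a number. Compound 1 therefore stands at the weak end of the numbers shown, at the limit of > 100000 nM in this assay, at which 1 of the 3 values shown sits. Two other compounds on a different core were measured alongside it. Compound 2, with the structure `Cc1ccc2[nH]c3c(c4c(c5ccnn53)C(=O)NC4=O)c2c1`, gives 9000 nM in this assay. Compound 3, with the structure `Cc1ccc2[nH]c(-n3cccn3)c(C3=C(Br)C(=O)NC3=O)c2c1`, gives 15000 nM in this assay. For the measured compounds named here, neither of these differs from compound 1 in a single place, so no step can be drawn from them to compound 1.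

Compound 4 has the structure `COc1ccc2[nH]c(-n3cccn3)cc2c1`. It differs from compound 1 in one place: methoxy in place of hydrogen on an aromatic carbon. Going by the values given here, no measured step exists for a change of this kind, so the expectation for compound 4 rests on compound 1 alone. With compound 1 reporting only a limit, the step from compound 1 to compound 4 is expected to be a step that the limit leaves unreadable from compound 1 to compound 4, likely no more than the usual scatter in either direction. On that basis compound 4 is estimated at 150000 nM in this assay, within a range from 40000 nM to 500000 nM, and it may again report only a limit.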

Compound 4, half-maximal inhibitory concentration: > 100000 nM
Compound 4: only a limit was reported; the forecaster's own chance of this, stated with the estimate: 75%; the middle value lies beyond the limit too.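

Compound 1 and compound 4 each report only a limit in this assay, so no step between them can be read: the limit of > 100000 nM in this assay, at which 2 of the 4 values shown sit.

The compounds shown leave open whether methoxy in place of hydrogen on an aromatic carbon changes cytotoxicity at all.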